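The compounds below may be only part of what the source reports. "The series", "measured", "known", "first", "only" and "open" are said of these compounds alone.

Measured compounds:
- compound 1, `CCCCC#Cc1cc(C(=O)OCC)nc2ccc(OC)cc12`: 7200 nM
- compound 2, `CCOC(=O)c1cc([Se]Cc2ccccc2)c2cc(Cl)ccc2n1`: 84500 nM

Among the compounds with values here, in a functional assay on SK-MEL-147 cells (Homo sapiens) for cytotoxicity, read by MTT assay, with a stated time of 24 h (a lower number here means that less compound is needed, a higher number that more compound is needed for the effect), compound 1 gives 7200 nM and stands lowest of the two numbers known here; the nearest, compound 2, gives 84500 nM in this assay, a gap that lies beyond the usual scatter. Compound 3, `CCOC(=O)c1cc(C#CCCO)c2cc(OC)ccc2n1`, has not yet been measured in this assay. It differs from compound 1 in one place only: hydroxy in place of ethyl on a saturated chain carbon, two bonds along the chain from a triple-bonded carbon. The alkyne on the shared core is kept, and only its chain end is altered, hex-1-yn-1-yl becoming 4-hydroxybut-1-yn-1-yl. Within the data shown here, no measured pair shows this kind of change, so the expectation rests on compound 1 alone. The step is expected to be small, toward a somewhat higher number, and may well fall within the scatter; the estimate for a 1.7-fold higher number from compound 1 to compound 3 (0.22 log units; within the scatter) reflects that. Compound 3 is accordingly expected to give about 12000 nM in this assay, within a range from 4000 nM to 40000 nM.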

Compound 3, half-maximal effective concentration: > 150000 nM
Compound 3: no number, only a limit; the forecaster's own chance of this, stated with the estimate: 15%; middle value at least 12-fold (1.09 log units) away from the limit.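

On the shared core, the end of the alkyne chain proved far from indifferent in this assay: hydroxy in place of ethyl on a saturated chain carbon, two bonds along the chain from a triple-bonded carbon, gives an at least 20-fold higher number from compound 1 to compound 3 (1.31 log units; beyond the scatter). Before this pair, nothing showed how this position responded to any change, since compound 1 was the only compound with an alkyne at this place. The entry for compound 3 is a limit and not a number, so the full size of the step remains unknown: the limit of > 150000 nM in this assay, at which 1 of the 3 values shown sits.

This one pair cannot separate the loss of ethyl from the gain of hydroxy. It also leaves open whether an amine at the chain end, or a longer chain ending in hydroxy, would behave like compound 1 or like compound 3.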